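One fluorinated group swapped for trifluoromethyl in compound 2

The compounds below may be only part of what the source reports. "The series", "measured", "known", "first", "only" and "open" are said of these compounds alone.

Measured in a functional assay on DU-145 cells (Homo sapiens) for antiproliferative activity, read by propidium iodide staining, with a stated time of 96 h; a higher number here means a weaker inhibitor, a lower number a stronger inhibitor:
- compound 1 `CC(O)(COc1ccc(C#N)cc1C(F)(F)F)C(=O)Nc1ccc(S(F)(F)(F)(F)F)cc1`: 21200 nM
- compound 2 `CC(O)(COc1ccc(S(F)(F)(F)(F)F)cc1)C(=O)Nc1cccc(S(F)(F)(F)(F)F)c1`: 12800 nM

The two values lie within the usual scatter of repeated measurements, so neither compound 1 nor compound 2 can be called the stronger inhibitor. Compound 3 `CC(O)(COc1ccc(C(F)(F)F)cc1)C(=O)Nc1cccc(S(F)(F)(F)(F)F)c1` has not yet been measured. It is compound 2 with a single change: a group of 4 heavy atoms (1 carbon, 3 fluorine; no ring) in place of a group of 6 heavy atoms (5 fluorine, 1 sulfur; no ring), on an aromatic carbon. The trifluoromethyl sits on an aromatic carbon, para to a large group.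

Going by the values given here, no measured pair differs in just one place, so the data give no direct guide to the size of this change. Compound 1 differs from compound 2 in more than one place, yet compound 1 gives 21200 nM, within the scatter of compound 2. No shift beyond the scatter is expected in either direction in this assay. The estimated step is small: a 1.3-fold higher number from compound 2 to compound 3 (0.10 log units; within the scatter). For compound 3, the expected value is 16000 nM, with an estimated range of 7000 nM to 36000 nM.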

Compound 3, half-maximal inhibitory concentration: 13600 nM
For compound 3 the middle estimate is 1.2-fold (0.07 log units) above the measured one; measured number inside the range.
By their numbers in this assay, from the lowest: compounds 2, 3 and 1 (each within the scatter of the next).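

Going by these compounds alone, compound 2 and compound 3 are the first pair here that differ in one place only, so they give the first direct reading of this position in this assay for a single swap. Trifluoromethyl replaces the group of 5 fluorine atoms and 1 sulfur atom on the aromatic carbon, para to a large group, and the step is a 1.1-fold higher number from compound 2 to compound 3 (0.03 log units; within the scatter), so the two groups cannot be told apart at this position in this assay. No measurement is available that bears on this result.

The compounds shown leave open whether a different kind of group at this position, such as an amine or a carboxylic acid, would move the number beyond the scatter. They also leave open whether the same swap would read alike elsewhere on the molecule, where compound 3 still carries the sulfur group.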